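Removing the isopropyl from compound 1: expected loss of potency

A few compounds are considered here, and "the series" means these few. Any claim that something is new, unique, unknown or untested is made for them only; others in the source may bear on it.

Measured compounds:
compound 1 `CC(C)c1ccc(-c2nc3sccn3c2/C=N/OCc2ccc(Cl)c(Cl)c2)cc1`: 590 nM
compound 2 `COc1ccc(CO/N=C/c2c(-c3ccc4ccccc4c3)nc3occn23)cc1`: 4400 nM

In an assay on HepG2 cells for agonist activity at nuclear receptor subfamily 1 group I member 3 (Homo sapiens), read by a luciferase reporter, with a stated time of 23 h (a lower number here means that less compound is needed, a higher number that more compound is needed for the effect), compound 1 gives 590 nM, the lowest of the two numbers recorded. Going by the values given here, the only other measured compound, compound 2, gives 4400 nM in this assay, a value beyond the scatter above that of compound 1; the two compounds differ in several places at once, so no single step between them can be read.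

Compound 3 `Clc1ccc(CO/N=C/c2c(-c3ccccc3)nc3sccn23)cc1Cl` has not been measured in this assay. It is related to compound 1 by one change: hydrogen in place of isopropyl on an aromatic carbon. The isopropyl leaves and a hydrogen takes its place on an aromatic carbon of a six-membered aromatic ring of carbon only, so that the 4-isopropylphenyl becomes a plain phenyl, while the rest of compound 1 is unchanged.

Among the compounds with values here, no measured pair in this set shows what this change does. Compound 3 is estimated to need more compound than compound 1, a step of a 3.4-fold higher number from compound 1 to compound 3 (0.53 log units; beyond the scatter) expected to lie beyond the scatter. For compound 3 the expected value in this assay is 2000 nM, with a range from 600 nM to 7000 nM.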

Compound 3, half-maximal effective concentration: 580 nM
Beside the measured number, compound 3's estimate is 3.4-fold (0.54 log units) above it; measured number below the stated range.
By their numbers in this assay, from the lowest: compounds 3 and 1 (each within the scatter of the next); then compound 2.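

In this assay, the step on replacing the isopropyl with hydrogen reads a 1.0-fold lower number from compound 1 to compound 3 (0.01 log units; within the scatter), so the two compounds cannot be told apart. Until this pair, nothing showed what the group on this aromatic carbon, para to a large group, contributes; with the rest of compound 1 unchanged, the plain phenyl and the 4-isopropylphenyl give the same reading within the scatter, so the isopropyl is not needed to hold the number at this level in this assay. No measurement at hand offers a reason for this result.

What the compounds shown leave open is whether this indifference extends beyond hydrogen and isopropyl, since a carboxylic acid, an amine or a longer chain such as n-butyl on the same aromatic carbon might read quite differently. Going by these compounds alone, it is also open whether the same change would read the same way in the setting of compound 2, which differs from compound 1 and compound 3 in several places at once, so that no step to it can be read.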